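The source may hold more compounds than are shown below. What is called first, only, known or untested is meant among the compounds shown, and "the series" means these compounds.

Measured to date in a functional assay on NCI-H460 cells (Homo sapiens) for cytotoxicity, read by MTT assay; a lower number here means a stronger inhibitor, a higher number a weaker inhibitor:

Compound 1 `COc1ccc(/C=C/C(=O)c2sc(Nc3ccc(Cl)cc3)nc2C)cc1`: > 25000 nM, a limit of the assay rather than a number.
Compound 2 `COc1cccc(/C=C/C(=O)c2sc(Nc3cccc(C)c3)nc2C)c1`: > 25000 nM, also a limit.
Compound 3 `COc1cc(/C=C/C(=O)c2sc(Nc3cccc(Cl)c3)nc2C)cc(OC)c1OC`: > 25000 nM, again a limit.

Compound 3 therefore sits at the top of the measured range, on (the limit of > 25000 nM in this assay, at which 3 of the 3 values shown sit), and no ranking among the three is possible. Compound 4 `COc1cc(/C=C/C(=O)c2sc(Nc3ccc(C)cc3)nc2C)cc(OC)c1OC` differs from compound 3 only by 4-methylphenyl in place of 3-chlorophenyl on a nitrogen on an aromatic ring. Within the data shown here, no measured pair isolates this change, so no direction can be read from the numbers. Compound 4 is expected to remain at the limit, with a step that the limit leaves unreadable from compound 3 to compound 4 that means none beyond the scatter. Compound 4 is estimated at 30000 nM, from 12000 nM to 80000 nM, most likely reported again only as a limit.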

Compound 4, half-maximal inhibitory concentration: > 25000 nM
Compound 4 was reported as a limit; the forecaster's own chance of this, stated with the estimate: 80%; the middle value is on the limit's open side.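

In this assay, compound 3 and compound 4 are both reported only as limits, so no step between them can be read: the limit of > 25000 nM in this assay, at which 4 of the 4 values shown sit.

The compounds shown leave open whether any change on the shared core gives a readable value in this assay.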